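Swapping Methoxy for Methyl on an Inactive Benzoylthiophene Acid

The source may report more compounds than this note shows. Statements on the series, on what has been measured and on what is new or still open speak of the compounds shown alone.

Compound 1 `COc1ccc(C(=O)c2sc(Nc3ccccc3)c(C(=O)O)c2C)cc1` is tested in a functional assay, with a stated time of 150 min, tested at 30 ug/mL (on this read-out higher numbers stand for a stronger effect at the one concentration tested and lower numbers for a weaker effect), and gives 59.5% there. Compound 2 `COc1ccc(C(=O)c2sc(Nc3ccc(Cl)cc3)c(C(=O)O)c2C)cc1` carries a chlorine on its aniline ring, and in this assay compound 2 is reported as "not active" (no number reported) with no number attached, so its position on the scale cannot be placed more closely. Compound 3 `Cc1ccc(C(=O)c2sc(Nc3ccc(Cl)cc3)c(C(=O)O)c2C)cc1` differs from compound 2 in one place: methyl in place of methoxy on an aromatic carbon. Among the compounds with values here, no step between measured compounds covers this change. With compound 2 at "not active" (no number reported), the expected outcome for compound 3 is a weak read-out, estimated at 15% with a range from 0% to 45%.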

Compound 3, a percentage reported as activity, at one concentration (the size of the read-out at that concentration, not a potency): "not active" (no number reported)
Nothing numeric was reported for compound 3; no gap can be computed for the estimate.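

In this assay compound 2 and compound 3 are both reported as not active without a number, so no step can be read between them. As far as these compounds go, whether methyl in place of methoxy changes the effect on a compound with a measurable read-out stays open. No evidence bears on this result.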